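Stripping the Triazole Side Chain Down to Hydrogen

A few compounds are considered here, and "the series" means these few. Any claim that something is new, unique, unknown or untested is made for them only; others in the source may bear on it.

Of the compounds shown here, three on a shared core have been tested in a functional assay on CFPAC-1 cells (Homo sapiens) for antiproliferative activity, read by MTT assay, with a stated time of 72 h; a lower number here means a stronger inhibitor, a higher number a weaker inhibitor. Compound 1 `Cc1ccc(S(=O)(=O)NCc2cn(C[C@H](O)[C@H]3OC(=O)C(OCc4ccccc4)=C3OCc3ccccc3)nn2)cc1` gives 68000 nM. Compound 2 `O=C1O[C@H]([C@@H](O)Cn2cc(CCO)nn2)C(OCc2ccccc2)=C1OCc1ccccc1` reaches only the limit of > 100000 nM, which marks the edge of the measurement rather than a number. Compound 3 `O=C1O[C@H]([C@@H](O)Cn2cc(-c3ccc(Br)cc3)nn2)C(OCc2ccccc2)=C1OCc1ccccc1` gives 5830 nM. Of the two numbers, compound 1 carries the higher one: the step of a 12-fold lower number from compound 1 to compound 3 (1.07 log units; beyond the scatter) separates it from compound 3, while the step of an at least 1.4-fold higher number from compound 1 to compound 2 (0.16 log units; that floor lies within the scatter) runs to the limit (the limit of > 100000 nM in this assay, at which 1 of the 3 values shown sits).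

Compound 4 `O=C1O[C@H]([C@@H](O)Cn2ccnn2)C(OCc2ccccc2)=C1OCc1ccccc1` has not been measured. It differs from compound 1 in one place: hydrogen in place of (((4-methylphenyl)sulfonyl)amino)methyl on an aromatic carbon. Two measured steps start from compound 1 and change the same group. The swap to 4-bromophenyl gave a 12-fold lower number from compound 1 to compound 3 (1.07 log units; beyond the scatter), and the swap toward the hydroxyl-bearing chain gave an at least 1.4-fold higher number from compound 1 to compound 2 (0.16 log units; that floor lies within the scatter). Among these compounds only the 4-bromophenyl brought a lower number; the other change moved the value to the limit. Removing the group entirely is a change neither step covers directly, so a small step, more likely toward a higher number than a lower one, is expected in this assay.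

Compound 4 is therefore expected at 90000 nM. Compound 4 would then sit between 30000 nM and 250000 nM, an expected step of a 1.3-fold higher number from compound 1 to compound 4 (0.12 log units; within the scatter).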

Compound 4, half-maximal inhibitory concentration: > 100000 nM
Compound 4 ended at the assay's limit; the forecaster's own chance of this, stated with the estimate: 40%; middle value at least 1.1-fold (0.04 log units) away from the limit.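

Compound 4 stands at a limit, not a number, and with compound 2 also at a limit the step between them cannot be read: the limit of > 100000 nM in this assay, at which 2 of the 4 values shown sit.

Taking the 4-bromophenyl away gives an at least 17-fold higher number from compound 3 to compound 4 (1.23 log units; beyond the scatter), so the number of compound 3 belongs to the shared core carrying that group and not to the core alone. Removing the (((4-methylphenyl)sulfonyl)amino)methyl gives an at least 1.4-fold higher number from compound 1 to compound 4 (0.16 log units; that floor lies within the scatter), a floor that lies within the scatter, so these compounds cannot show that this large group adds anything over plain hydrogen, and the true size of the step stays hidden behind the limit.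

Going by these compounds, whether the lower number of compound 3 comes from the bromine or from the six-membered aromatic ring that carries it stays open, and a plain phenyl or a 4-chlorophenyl on this aromatic carbon would separate the two. On these data alone, it is also open how an aminomethyl group or a carboxylic acid at the same place would read in this assay.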